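Methyl on the indole ring carbon: an untested change

The source may report more compounds than this note shows. Statements on the series, on what has been measured and on what is new or still open speak of the compounds shown alone.

Compound 1, `COC(=O)[C@@]1(C)CCC=C2[C@@H]1CC[C@@H](C)[C@]2(C)Cc1c[nH]c2ccc(Br)cc12`, gives 12000 nM in a functional assay on SW1573 cells (Homo sapiens) for inhibition, read by sulforhodamine B assay, with a stated time of 48 h; a higher number here means a weaker inhibitor of growth, a lower number a stronger inhibitor of growth.
Compound 2, `COC(=O)[C@@]1(C)CCC=C2[C@@H]1CC[C@@H](C)[C@]2(C)Cc1c[nH]c2ccc(F)cc12`, gives 7300 nM in this assay.
Compound 3, `COC(=O)[C@@]1(C)CCC=C2[C@@H]1CC[C@@H](C)[C@]2(C)Cc1c[nH]c2ccc(OC)cc12`, gives 1300 nM in this assay.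

Compound 1 stands at the highest number of the three. Compound 2 sits close to it: the step of a 1.6-fold lower number from compound 1 to compound 2 (0.22 log units; within the scatter) stays within the scatter. Compound 3 is clearly apart: the step of a 9.2-fold lower number from compound 1 to compound 3 (0.97 log units; beyond the scatter) and the step of a 5.6-fold lower number from compound 2 to compound 3 (0.75 log units; beyond the scatter) both go beyond it.

Compound 4, `COC(=O)[C@@]1(C)CCC=C2[C@@H]1CC[C@@H](C)[C@]2(C)Cc1c(C)[nH]c2ccc(Br)cc12`, differs from compound 1 in one place: methyl in place of hydrogen on an aromatic carbon. Among the measured compounds shown here, none of the measured steps touches that place. All of them swap the group on the six-membered part of the fused ring system, while the bromo of compound 1 is kept in compound 4. The measured steps therefore give no direct guidance, and the safest expectation is a change in this assay that stays within the scatter. Compound 4 is estimated at 10000 nM, within 4000 nM to 30000 nM, which corresponds to an expected step of a 1.2-fold lower number from compound 1 to compound 4 (0.08 log units; within the scatter).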

Compound 4, concentration for 50% growth inhibition: 14000 nM
The estimate for compound 4 lay 1.4-fold (0.15 log units) below the measured number; the range from low to high includes it.
By their numbers in this assay, from the lowest: compound 3; then compounds 2, 1 and 4 (each within the scatter of the next).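

Among the compounds shown here, the step of a 1.2-fold higher number from compound 1 to compound 4 (0.07 log units; within the scatter) is the first look at the carbon of the five-membered aromatic ring next to the ring nitrogen, and it shows that a methyl there, with the bromo kept, gives a number in this assay that cannot be told apart from that of compound 1. So this place accepts one added carbon without a change beyond the scatter, whereas swapping bromo for methoxy on the six-membered part gave the step of a 9.2-fold lower number from compound 1 to compound 3 (0.97 log units; beyond the scatter). Nothing shown here explains why the methyl makes so little difference.

Going by these compounds, it remains open whether a longer chain such as ethyl, or an amine or a carboxylic acid, would be accepted at this same carbon. On these data alone, it is also open whether the methyl would be equally silent alongside the methoxy of compound 3, the compound with the lowest number here.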